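The source may report more compounds than this note shows. Statements on the series, on what has been measured and on what is new or still open speak of the compounds shown alone.

Measured so far, in a functional assay on CHO cells for antagonist activity at Orexin/Hypocretin receptor type 1 (Homo sapiens), read by FLIPR and calcium flux; a lower number here means a stronger inhibitor, a higher number a weaker inhibitor:
compound 1, `CNC(=O)[C@@H](c1ccccc1)N1CCn2c(COC)nc(Cl)c2[C@@H]1CCc1ccc(C(F)(F)F)cc1`: 1650 nM
compound 2, `CCc1nc(OC)c2n1CCN([C@@H](C(=O)NC)c1ccccc1)C2CCc1ccc(C(F)(F)F)cc1`: 134 nM

Compound 1 holds the highest of the two numbers in this assay. The nearest value is that of compound 2, which gives 134 nM, a lower number by a margin beyond the scatter. Compound 2 differs from compound 1 in more than one place, so that pair shows only its two values and nothing about any single change.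

Compound 3, `CNC(=O)[C@@H](c1ccccc1)N1CCn2c(C)nc(Cl)c2[C@@H]1CCc1ccc(C(F)(F)F)cc1`, is not yet measured in this assay. It differs from compound 1 in one place: hydrogen in place of methoxy on a saturated chain carbon bound to an aromatic carbon. Among the measured compounds shown here, no measured pair shows this change on its own, so there is no step to lean on. The step of a 1.7-fold lower number from compound 1 to compound 3 (0.22 log units; within the scatter) is expected to be small, at most a mild lowering of the number, and may well be none beyond the scatter. Compound 3 is therefore expected to give 1000 nM in this assay, with a range from 300 nM to 3500 nM.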

Compound 3, half-maximal inhibitory concentration: 90 nM
Compound 3: the middle estimate sits 11-fold (1.05 log units) above what was measured; measured number below the stated range.
By their numbers in this assay, from the lowest: compounds 3 and 2 (each within the scatter of the next); then compound 1.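

In this assay, the place on a saturated chain carbon bound to an aromatic carbon turns out to be sensitive, since a single change, methoxymethyl to methyl, gives an 18-fold lower number from compound 1 to compound 3 (1.26 log units; beyond the scatter). The earlier pair differed in more than one place and could not tie any difference to one group, whereas this pair holds everything else constant and assigns the whole step to that change. The group that leaves is methoxy, with 2 heavy atoms and 1 hydrogen-bond acceptor, but no measurement here explains the size of the step or separates the contribution of the oxygen from that of the chain length.

Going by these compounds, it remains open whether hydroxymethyl, aminomethyl or a longer chain such as propyl at this place would give a number close to that of compound 3 or close to that of compound 1, so the shape of the trend at this place is still undefined. On these data alone, it is also open whether the same change gives a step of similar size on other versions of the core, and compound 2 cannot settle this, as it differs from both compound 1 and compound 3 in more than one place.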